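Working notes: from compound 3 to compound 4

The compounds below may be only part of what the source reports. "The series", "measured", "known", "first", "only" and "open" are said of these compounds alone.

Three compounds of the series have been run so far, all on a shared core. Compound 1 `COc1cc(OC)c(OC)cc1/C=C/C(=O)c1ccc(OC)c2c1OC(C)(C)C=C2` in a functional assay on HCT-116 cells (Homo sapiens) for antiproliferative activity, read by MTT assay, with a stated time of 24 h (on this read-out lower numbers stand for stronger inhibition and higher numbers for weaker inhibition), gives only a limit of the assay, > 10000 nM. Compound 2 `COc1ccc(C(=O)/C=C/c2ccc(-n3ccnc3)cc2)c2c1C=CC(C)(C)O2` in this assay likewise gives only a limit, > 10000 nM. Compound 3 `COc1ccc(C(=O)/C=C/c2ccsc2)c2c1C=CC(C)(C)O2` in this assay also gives only a limit, > 10000 nM. Among the compounds with values here, compound 3 therefore stands with the other two at the limit of > 10000 nM in this assay, at which 3 of the 3 values shown sit; no number is known for any of them, and no step between measured compounds can be read from these values.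

Compound 4 `COc1ccc(C(=O)/C=C/c2cc(Cl)ccc2O)c2c1C=CC(C)(C)O2` remains to be measured in this assay. It differs from compound 3 by 5-chloro-2-hydroxyphenyl in place of thiophen-3-yl on a double-bonded chain carbon bound to a double-bonded chain carbon. Within the data shown here, since every known value sits at the limit, there is no measured step to lean on. The step from compound 3 to compound 4 is expected to be a step that the limit leaves unreadable from compound 3 to compound 4, that is, nothing clearly beyond the scatter and quite possibly a further limit. For compound 4 the expected value in this assay is 15000 nM, within a range of 4000 nM to 50000 nM.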

Compound 4, half-maximal inhibitory concentration: 5240 nM
For compound 4 the middle estimate is 2.9-fold (0.46 log units) above the measured one; the measured number falls inside the stated range.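

In this assay, exchanging the thiophen-3-yl group for the 5-chloro-2-hydroxyphenyl group gives an at least 1.9-fold lower number from compound 3 to compound 4 (0.28 log units; that floor lies within the scatter). Compound 4 is the only compound shown with a number rather than a limit, 5240 nM, so this position on the shared core can carry a value that is readable in this assay. The size of the step remains only a floor, and the steps to compound 1 and compound 2 cannot be read: the limit of > 10000 nM in this assay, at which 3 of the 4 values shown sit.

The compounds shown do not separate the contribution of the hydroxy group from that of the chlorine in 5-chloro-2-hydroxyphenyl. They also leave open how an unsubstituted phenyl or an aminophenyl would read at this position.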